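Swapping the sulfonyl aryl group: 4-fluorophenyl to 2-methylphenyl

This account rests on a few compounds, and the source may have more. Where it says the series, first, only, none or still open, it means among the compounds named here.

Measured so far:
compound 1 `CCCCC(CC)C(=O)Nc1ccc2ccn(Cc3ccc(C(=O)NS(=O)(=O)c4ccc(F)cc4)cc3OC)c2c1`: 7.7
compound 2 `COc1cc(C(=O)NS(=O)(=O)c2ccccc2C)ccc1Cn1ncc2ccc(NC(=O)CC3CCCC3)cc21`: 10.9

Among the measured compounds shown here, in a functional assay (trachea) for antagonist activity, with Cavia porcellus as the target (a higher number here means a more potent compound, by a factor of ten per unit of this negative logarithm, a lower number a less potent compound), compound 1 gives 7.7, the lower of the two numbers known here. Compound 2 stands well above it, a gap beyond the scatter, but the two compounds differ in several places at once, so no single cause can be read from that gap.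

Compound 3 `CCCCC(CC)C(=O)Nc1ccc2ccn(Cc3ccc(C(=O)NS(=O)(=O)c4ccccc4C)cc3OC)c2c1` has not been measured. It differs from compound 1 in one place only: 2-methylphenyl in place of 4-fluorophenyl on a sulfonyl sulfur. Compound 3 thus carries the same group on the sulfonyl sulfur as compound 2, while keeping the core and amide chain of compound 1.

A moderate rise is expected for compound 3, because compound 2, which shares this group, gives 10.9. The step from compound 1 is estimated as a number 0.70 log units higher from compound 1 to compound 3 (beyond the scatter). Compound 3 is expected to reach 8.4, within a range of 7.4 to 9.8.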

Compound 3, negative logarithm of the antagonist equilibrium constant: 8.9
Beside the measured number, compound 3's estimate is 0.50 log units below it, within the range that was stated.
By their numbers in this assay, from the lowest: compound 1; then compound 3; then compound 2.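

In this assay, among the compounds shown here, the step is a number 1.20 log units higher from compound 1 to compound 3 (beyond the scatter) and the core and amide chain stay the same, so this gap, unlike the one between compound 1 and compound 2, belongs to a single place: the aryl group on a sulfonyl sulfur whose other neighbour is an amide-type nitrogen. The two groups match in heavy-atom count, with one six-membered aromatic ring of carbon only, no hydrogen-bond donors or acceptors and no net charge, so those counts do not separate them. No measurement shown here explains the size of this step.

As far as these compounds go, it remains open how much of the step comes from removing the 4-fluorophenyl group and how much from adding the 2-methylphenyl group, a question that an unsubstituted phenyl group on the same sulfur would help to answer. How a chlorophenyl group would fare at this place is also unknown.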